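The source may hold more compounds than are shown below. What is called first, only, known or untested is meant among the compounds shown, and "the series" means these compounds.

Compound 1 `CCCCNc1nc(N)nc2cccc(C(=O)NC)c12` carries a methyl on the amide nitrogen of the shared core, and in an ADME assay on HEK293 cells for agonist activity at Toll-like receptor 8 (Homo sapiens), read by a luciferase reporter, with a stated time of 6 h (a lower number here means that less compound is needed, a higher number that more compound is needed for the effect), compound 1 gives 0.39 uM. Compound 2 `CCCCNc1nc(N)nc2cccc(C(=O)N(C)Cc3ccccc3)c12` carries benzyl and methyl on that nitrogen. In this assay compound 2 reaches only a limit, > 25 uM. Compound 3 `CCCCNc1nc(N)nc2cccc(C(=O)N[C@@H](C)c3ccccc3)c12` carries 1-phenylethyl on the amide nitrogen. For compound 3 this assay likewise reports a limit, > 25 uM. Compound 3 stands at the limit shared by two of the three values shown (the limit of > 25 uM in this assay, at which 2 of the 3 values shown sit). The step of an at least 64-fold higher number from compound 1 to compound 3 (1.80 log units; beyond the scatter) and the step of an at least 64-fold higher number from compound 1 to compound 2 (1.80 log units; beyond the scatter) are both large, while the step that the two limits leave unreadable from compound 2 to compound 3 cannot be read from two limits. Compound 4 `CCCCNc1nc(N)nc2cccc(C(=O)N[C@@H](C)c3cccc(OC)c3)c12` differs from compound 3 in one place: methoxy in place of hydrogen on an aromatic carbon, the phenyl turning into 3-methoxyphenyl. Within the data shown here, no measured step alters a substituent on that ring; the only guide is that compound 3 already sits at the limit. Compound 4 is expected to sit there as well, which means an expected step of a number no higher from compound 3 to compound 4 (the limit leaves the size open) of no readable size. The estimate for compound 4 is 25 uM, with a range from 5 uM to 100 uM.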

Compound 4, minimum effective concentration: > 25 uM
Compound 4: only a limit was reported; the forecaster's own chance of this, stated with the estimate: 85%; the middle value lies on the limit itself.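

Among these compounds, compound 3 and compound 4 both reach only a limit in this assay, so no step between them can be read: the limit of > 25 uM in this assay, at which 3 of the 4 values shown sit.

The compounds shown leave open how far compound 2, compound 3 and compound 4 lie past that limit, and whether methoxy on the phenyl makes any difference.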